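Series notes: compound 2 to compound 3, cytotoxicity

The source may hold more compounds than are shown below. What is called first, only, known or untested is meant among the compounds shown, and "the series" means these compounds.

compound 1 `CCCCCCCc1cn(C(c2ccccc2)c2cc3cc(Br)ccc3nc2OC)nn1`: 0.17%
compound 2 `COc1nc2ccc(Br)cc2cc1C(c1ccccc1)n1cc(-c2ccccc2F)nn1`: 3.97%

In an ADME assay on HEK293 cells (Homo sapiens) for cytotoxicity, read by sulforhodamine B assay, with a stated time of 48 h, tested at 10 uM (a lower number here means less inhibition, a higher number more inhibition at the concentration tested (going by the name of the read-out)), compound 1 gives 0.17% and compound 2 gives 3.97%. Compound 2 gives the larger of the two numbers, but the step of a number 3.8 percentage points higher from compound 1 to compound 2 (within the scatter) lies within the scatter, so the two are not distinguished. Compound 3 `CCOC(=O)c1cn(C(c2ccccc2)c2cc3cc(Br)ccc3nc2OC)nn1` differs from compound 2 by ethoxycarbonyl in place of 2-fluorophenyl on an aromatic carbon. Going by the values given here, the only measured step that bears on this, that from compound 1 to compound 2, was within the scatter. The expected step is a number 1 percentage points lower from compound 2 to compound 3 (within the scatter), no change beyond the scatter. Compound 3 is estimated at 3%, in the range -5% to 12%.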

Compound 3, a percentage reported as inhibition, at one concentration (the size of the read-out at that concentration, not a potency): 2%
Estimate against measurement, compound 3: 1 percentage points above; measured number inside the range.
By their numbers in this assay, from the lowest: compounds 1, 3 and 2 (each within the scatter of the next).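

In this assay, ethoxycarbonyl, which has no ring and brings hydrogen-bond acceptors, gives a number 2 percentage points lower from compound 2 to compound 3 (within the scatter) and a number 1.8 percentage points higher from compound 1 to compound 3 (within the scatter). A chain, an aromatic ring and a non-ring carbonyl group at this position are therefore not distinguished in this read-out, so the earlier finding extends to a third, different type of group. No supporting data bear on this result.

As far as these compounds go, whether any group at this position moves the number beyond the scatter stays open. A primary amine or a carboxylic acid would test this.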